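A few compounds are considered here, and "the series" means these few. Any claim that something is new, unique, unknown or untested is made for them only; others in the source may bear on it.

In a functional assay on MCF7 cells (Homo sapiens) for cytotoxicity, read by MTT assay, with a stated time of 72 h (on this read-out lower numbers stand for stronger inhibition and higher numbers for weaker inhibition), compound 1 `CNC(=O)c1cc(Oc2ccc(NC(=O)c3nccc(-c4ccccc4)n3)cc2)ccn1` gives 39100 nM and compound 2 `CNC(=O)c1cc(Oc2ccc(NC(=O)c3cc(-c4ccc(C)cc4)ncn3)cc2)ccn1` gives 34600 nM, two values within the scatter of each other. Compound 3 `CCc1ccc(-c2cc(C(=O)Nc3ccc(Oc4ccnc(C(=O)NC)c4)cc3)ncn2)cc1` gives 6350 nM, lower than both and beyond the scatter. Compound 1 therefore sits with compound 2 at the high-number end of this small set, which means weak inhibition of these cells.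

Compound 4 `CNC(=O)c1cc(Oc2ccc(NC(=O)c3nccc(-c4ccc([N+](=O)[O-])cc4)n3)cc2)ccn1`, still to be measured, keeps the core of compound 1 and changes one place, phenyl to 4-nitrophenyl: nitro in place of hydrogen on an aromatic carbon.

Among the compounds with values here, no measured pair carries this change, so the data offer no direct guide. Within the data shown here, the only single-place step available is a 5.4-fold lower number from compound 2 to compound 3 (0.74 log units; beyond the scatter), where methyl replaces hydrogen on a saturated chain carbon bound to an aromatic carbon. That step involves a different group, and it shows only that one small addition can move the number beyond the scatter in this assay. A shift in the same direction but smaller is therefore expected, with a result inside the scatter still quite possible. The expected change is a 2.0-fold lower number from compound 1 to compound 4 (0.29 log units; within the scatter). For compound 4 the estimated value is 20000 nM, with an expected range from 6000 nM to 50000 nM.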

Compound 4, half-maximal inhibitory concentration: > 100000 nM
Compound 4 gave a limit, no number; the forecaster's own chance of this, stated with the estimate: 10%; middle value at least 5.0-fold (0.69 log units) from the limit.
By their numbers in this assay, from the lowest: compound 3; then compounds 2 and 1 (each within the scatter of the next). At a limit, above all of these: compound 4.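

In this assay, putting nitro in place of hydrogen on the aromatic carbon para to a large group gives an at least 2.5-fold higher number from compound 1 to compound 4 (0.40 log units; beyond the scatter), a step beyond the scatter toward weaker inhibition of these cells. Within the data shown here, the only earlier step, a 5.4-fold lower number from compound 2 to compound 3 (0.74 log units; beyond the scatter), ran toward stronger inhibition and involved methyl on a saturated chain carbon, so this is the first sign that a change on an aromatic carbon of the outer phenyl ring can cost activity, and that a small addition can shift the number in either direction. The reading for compound 4 is a limit of the assay and not a number, so this step has a known direction but no exact size: the limit of > 100000 nM in this assay, at which 1 of the 4 values shown sits.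

The compounds shown leave open whether the loss belongs to nitro itself or would also follow from another group on the same carbon, such as an amine or a carboxylic acid. They also leave open whether nitro would act in the same way on the phenyl ring of compound 2 or compound 3, whose core differs from that of compound 1.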